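Metabolic stability notes: compound 2 to compound 3

A few compounds are considered here, and "the series" means these few. Any claim that something is new, unique, unknown or untested is made for them only; others in the source may bear on it.

Measured so far:
compound 1 `O=C(C=C1CCN(C(=O)c2ccc(F)cc2)CC1)N[C@@H]1CCN(Cc2ccc3cc(F)ccc3c2)C1`: 237 mL/min/kg
compound 2 `O=C(C=C1CCN(C(=O)c2ccc(Cl)cc2O)CC1)N[C@@H]1CCN(Cc2ccc3cc(F)ccc3c2)C1`: 87 mL/min/kg

Within the data shown here, in an in vitro ADME assay on microsomes from liver (Homo sapiens) for metabolic stability (a lower number here means slower removal, a higher number faster removal of the compound), compound 2 gives 87 mL/min/kg, the lower of the two numbers so far; the single step, a 2.7-fold lower number from compound 1 to compound 2 (0.44 log units; beyond the scatter), puts compound 1 clearly above it. Compound 3 `COc1cccc(O)c1C(=O)N1CCC(=CC(=O)N[C@@H]2CCN(Cc3ccc4cc(F)ccc4c3)C2)CC1` is not yet measured. It differs from compound 2 as follows: 2-hydroxy-6-methoxyphenyl in place of 4-chloro-2-hydroxyphenyl on a carbonyl carbon. Among the measured compounds shown here, the only measured step changed a different part of the aryl group, so no step bears directly on this change, and the hydroxyl of compound 2 is kept. With nothing in the data pointing either way, the expected step of a 1.1-fold higher number from compound 2 to compound 3 (0.06 log units; within the scatter) is taken as small, within or close to the scatter. Compound 3 is therefore estimated at 100 mL/min/kg, with a range from 50 mL/min/kg to 200 mL/min/kg.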

Compound 3, clearance: 192 mL/min/kg
The estimate for compound 3 lay 1.9-fold (0.28 log units) below the measured number; the range from low to high includes it.
By their numbers in this assay, from the lowest: compound 2; then compounds 3 and 1 (each within the scatter of the next).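

In this assay the aryl group on the carbonyl carbon stays a sensitive place even with its hydroxyl kept: 2-hydroxy-6-methoxyphenyl in place of 4-chloro-2-hydroxyphenyl gives a 2.2-fold higher number from compound 2 to compound 3 (0.34 log units; beyond the scatter). The hydroxyl therefore does not by itself go with the low number of compound 2, since against the 4-fluorophenyl group the step is a 1.2-fold lower number from compound 1 to compound 3 (0.09 log units; within the scatter), which leaves compound 1 and compound 3 indistinguishable here. No measurement in hand accounts for either step.

Because chlorine leaves and methoxy enters in the same change, the compounds shown do not separate the part played by each group. Also open, from the compounds shown here alone, is how this assay would read with a carboxylic acid or a primary amine on this aryl ring, or with a longer alkoxy chain in place of methoxy.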